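Swapping a Pyrazole for an Imidazole on the Shared Core

The source may report more compounds than this note shows. Statements on the series, on what has been measured and on what is new or still open speak of the compounds shown alone.

Compound 3 `CCOc1ccc2c(c1)C(c1cn[nH]c1)=CN(C)C(=O)[C@@H]2C` carries a 1H-pyrazol-4-yl group on its shared core. In a physicochemical assay for solubility (on this read-out higher numbers stand for higher solubility and lower numbers for lower solubility), compound 3 reaches only a limit, >= 115 ug/mL, as noted in the limit of >= 115 ug/mL in this assay, at which 1 of the 3 values shown sits. Its counterpart with a methyl on the aromatic nitrogen, compound 2 `CCOc1ccc2c(c1)C(c1cnn(C)c1)=CN(C)C(=O)[C@@H]2C`, gives a number, 143 ug/mL, so the step that the limit leaves unreadable from compound 2 to compound 3 cannot be sized. Compound 1 `C[C@H]1C(=O)N(C)C=Cc2cc(CN3CCCC3)ccc21` likewise sits at a limit, >= 97 ug/mL, described in the limit of >= 97 ug/mL in this assay, at which 1 of the 3 values shown sits. Compound 4 `CCOc1ccc2c(c1)C(c1c[nH]cn1)=CN(C)C(=O)[C@@H]2C` differs from compound 3 by 1H-imidazol-4-yl in place of 1H-pyrazol-4-yl on a double-bonded ring carbon. Among the compounds with values here, no measured step covers this change, and the limit on compound 3 leaves the starting point open, so no shift beyond the scatter is expected for a step that the limit leaves unreadable from compound 3 to compound 4. Compound 4 is therefore estimated at 150 ug/mL, within 60 ug/mL to 400 ug/mL.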

Compound 4, solubility: >= 131 ug/mL
Compound 4: no number, only a limit; the forecaster's own chance of this, stated with the estimate: 40%; the middle value does not contradict the limit.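

In this assay, within the data shown here, compound 4 gives only a limit, >= 131 ug/mL, so no step from compound 2 or compound 3 to compound 4 can be read. The compounds shown leave open whether 1H-imidazol-4-yl and 1H-pyrazol-4-yl differ at all on the shared core in this assay.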